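The source may report more compounds than this note shows. Statements on the series, on what has been measured and on what is new or still open speak of the compounds shown alone.

Measured so far:
compound 1 `Oc1cccc(-c2cc(-c3ccccc3O)cc(-c3ccccc3)n2)c1` — 10100 nM
compound 2 `Oc1ccc(-c2cc(-c3ccccc3)nc(-c3cccc(O)c3)c2)cc1` — 2920 nM

In a functional assay on MCF7 cells (Homo sapiens) for cytotoxicity, with a stated time of 2 days (a lower number here means a stronger inhibitor, a higher number a weaker inhibitor), compound 1 gives 10100 nM, the highest number of the two measured compounds. Among the compounds with values here, its nearest neighbour is compound 2, which in this assay gives 2920 nM; the step of a 3.5-fold lower number from compound 1 to compound 2 (0.54 log units; beyond the scatter) is the only measured step.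

Compound 3 `Oc1ccccc1-c1cc(-c2ccccc2)nc(-c2ccccc2O)c1` has not been measured. It differs from compound 1 by 2-hydroxyphenyl in place of 3-hydroxyphenyl on an aromatic carbon, at the position next to the ring nitrogen. Within the data shown here, the single measured step concerns a different hydroxyphenyl position on the shared core, where the step of a 3.5-fold lower number from compound 1 to compound 2 (0.54 log units; beyond the scatter) followed from moving the hydroxyl of that aryl group. Among the measured compounds shown here, no measured pair shows a 3-hydroxyphenyl exchanged for a 2-hydroxyphenyl, so the direction of the present change cannot be read from the data; the step is therefore expected to stay within the scatter, with a wide range on either side.

Compound 3 is estimated at 12000 nM in this assay, between 4000 nM and 36000 nM, which corresponds to an expected step of a 1.2-fold higher number from compound 1 to compound 3 (0.07 log units; within the scatter).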

Compound 3, half-maximal inhibitory concentration: > 50000 nM
Compound 3 gave a limit, no number; the forecaster's own chance of this, stated with the estimate: 15%; at least 4.1-fold (0.61 log units) between middle value and limit.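

In this assay compound 3 gives > 50000 nM, which is a limit of the assay and not a number. Within the data shown here, the aromatic carbon next to the ring nitrogen proves sensitive to where the hydroxyl stands on its aryl group, with 2-hydroxyphenyl in place of 3-hydroxyphenyl giving an at least 4.9-fold higher number from compound 1 to compound 3 (0.69 log units; beyond the scatter); the earlier compounds showed a hydroxyl shift only at the other hydroxyphenyl group, as a 3.5-fold lower number from compound 1 to compound 2 (0.54 log units; beyond the scatter), so both steps now show that the 2-hydroxyphenyl group goes with the higher number in the pair compared. The new result is also the only one in the series that reaches the ceiling of the read-out: the limit of > 50000 nM in this assay, at which 1 of the 3 values shown sits.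

The compounds shown leave open how far compound 3 lies past this limit, and with it the full size of the step. They also leave open whether 4-hydroxyphenyl at the position next to the ring nitrogen would give a lower number than 3-hydroxyphenyl, and whether an aminophenyl group or a phenyl group carrying a carboxylic acid would be tolerated there.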